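This account rests on a few compounds, and the source may have more. Where it says the series, first, only, none or still open, it means among the compounds named here.

Compound 1 `Cc1c(Cc2ccc(C(F)(F)F)cc2S(=O)(=O)c2ccccc2)c2c(n1CC(=O)O)CCNC2=O` gives 13 nM in a functional assay on CHO.K1 cells for antagonist activity at prostaglandin D2 receptor 2 (Homo sapiens), read by GTPgammaS binding, with a stated time of 1 h; a higher number here means a weaker inhibitor, a lower number a stronger inhibitor; compound 2 `COc1cccc(S(=O)(=O)c2ccccc2Cc2c3c(n(CC(=O)O)c2C)CCNC3=O)c1` gives 12 nM; compound 3 `CNC(=O)c1cccc(S(=O)(=O)c2ccccc2Cc2c3c(n(CC(=O)O)c2C)CCNC3=O)c1` gives 240 nM.

Compound 3 stands highest of the three numbers, a weaker inhibitor than compound 1 and than compound 2, both beyond the scatter. Among the compounds with values here, the one measured step that bears on the sulfonyl aryl is a 20-fold higher number from compound 2 to compound 3 (1.30 log units; beyond the scatter), a large step. Compound 4 `Cc1c(Cc2ccccc2S(=O)(=O)c2ccc(Cl)cc2)c2c(n1CC(=O)O)CCNC2=O` makes the change (4-chlorophenyl in place of 3-(methylcarbamoyl)phenyl on a sulfonyl sulfur), so the methylcarbamoyl group is gone and the ring, like those of compound 1 and compound 2, carries no hydrogen-bond donor or acceptor. Compound 4 is therefore expected to fall back toward the values of compound 1 and compound 2, a step of a 16-fold lower number from compound 3 to compound 4 (1.20 log units; beyond the scatter) in this assay. The estimate for compound 4 is 15 nM, between 5 nM and 50 nM.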

Compound 4, half-maximal inhibitory concentration: 8.5 nM
For compound 4 the middle estimate is 1.8-fold (0.25 log units) above the measured one, and the stated range covers the measured number.
By their numbers in this assay, from the lowest: compounds 4, 2 and 1 (each within the scatter of the next); then compound 3.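

In this assay the change on the sulfonyl sulfur gives a 28-fold lower number from compound 3 to compound 4 (1.45 log units; beyond the scatter) and restores a number level with that of compound 2, so the loss seen with 3-(methylcarbamoyl)phenyl does not extend to 4-chlorophenyl. Replacing 3-methoxyphenyl with 4-chlorophenyl gives a 1.4-fold lower number from compound 2 to compound 4 (0.15 log units; within the scatter) and so leaves the two rings unseparated in this assay. Nothing at hand explains why these numbers fall as they do.

As far as these compounds go, it remains open whether methylcarbamoyl would cost as much at the ring's 4-position, since the substituent and its place changed together here. From the compounds shown here alone, how a ring carrying an amine or a carboxylic acid would read also stays open.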